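A few compounds are considered here, and "the series" means these few. Any claim that something is new, unique, unknown or untested is made for them only; others in the source may bear on it.

Measured compounds: compound 1, `O=C(Nc1ccccc1Cl)N1CCN(c2nc(-c3ccc4ccccc4n3)no2)CC1`, gives 140 nM; compound 2, `O=C(NC1CCCCC1)N1CCN(c2nc(-c3ccc4ccccc4n3)no2)CC1`, gives 53 nM; compound 3, `O=C(NC1CCC(O)CC1)N1CCC(c2nc(-c3ccc4ccccc4n3)no2)CC1`, gives 2700 nM.

All three were tested in a functional assay on Shh Light II cells (Mus musculus) for inhibition, read by a luciferase reporter; on this read-out lower numbers stand for stronger inhibition and higher numbers for weaker inhibition. Compound 3 has the highest number of the three: it sits far above compound 1 and still further above compound 2, both gaps well beyond the scatter, so on these numbers it is the weakest inhibitor. Compound 4, `COc1ccccc1OC(=O)N1CCC(c2nc(-c3ccc4ccccc4n3)no2)CC1`, has not yet been measured. It differs from compound 3 in one place: 2-methoxyphenoxy in place of (4-hydroxycyclohexyl)amino on a carbonyl carbon. Among the compounds with values here, no measured step matches this change directly. Within the data shown here, the only measured step, a 2.6-fold lower number from compound 1 to compound 2 (0.42 log units; beyond the scatter), concerns the group on the amide-type nitrogen in a related pair and lowered the number modestly; the present change runs roughly the opposite way, an aromatic ring entering where a non-aromatic one leaves, while the hydrogen-bond donors are lost. That step is only a loose guide, so the expected outcome is a number in the same broad region as compound 3, with a wide range. Compound 4 is expected to give 1500 nM, between 300 nM and 7500 nM. This estimate means an expected step of a 1.8-fold lower number from compound 3 to compound 4 (0.26 log units; within the scatter).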

Compound 4, half-maximal inhibitory concentration: 250 nM
Beside the measured number, compound 4's estimate is 6.0-fold (0.78 log units) above it; the whole stated range lies above it.
By their numbers in this assay, from the lowest: compound 2; then compounds 1 and 4 (each within the scatter of the next); then compound 3.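

The group on this carbonyl carbon clearly matters: replacing (4-hydroxycyclohexyl)amino with 2-methoxyphenoxy gives an 11-fold lower number from compound 3 to compound 4 (1.03 log units; beyond the scatter) in this assay and so counts as a large change. The earlier compounds shown here showed only a modest step, at the amide-type nitrogen of a related pair, and gave no view of this position on the present core. Here, a six-membered aromatic ring on an oxygen link is compatible with stronger inhibition even though the entering group has no hydrogen-bond donors, but nothing shown explains the gain.

This single change alters the ring, the linking atom and the hydroxyl group together, so the compounds cannot show which of these accounts for the step. As far as these compounds go, how an unsubstituted phenoxy or a 2-methoxyphenylamino group would behave on this carbonyl carbon remains open.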